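A dimethyl for methoxy swap on the pendant phenyl

The source may hold more compounds than are shown below. What is called first, only, known or untested is meant among the compounds shown, and "the series" means these compounds.

Of the compounds shown here, three sharing one core have been measured in an assay on HEK293 cells for displacement of a labelled ligand from corticotropin-releasing factor receptor 1 (Homo sapiens); a higher number here means a weaker inhibitor, a lower number a stronger inhibitor. Compound 1 `CCCCCN(CCC)c1cc(C)nc2c(-c3ccc(Cl)cc3Cl)nn(C)c12` gives 1.2 nM, compound 2 `CCCCN(c1cc(C)nc2c(-c3ccc(Cl)cc3Cl)nn(C)c12)C(CC)CC` gives 7 nM, and compound 3 `CCCCN(CCCC)c1cc(C)nc2c(-c3ccc(OC)cc3Cl)nn(C)c12` gives 4.8 nM. Compound 3 stands second highest of the three numbers: its nearest neighbour is compound 2, whose value lies within the usual scatter of it, while compound 1 is furthest away, with a lower number beyond the scatter.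

Compound 4 `CCCCN(CCCC)c1cc(C)nc2c(-c3c(C)cc(C)cc3Cl)nn(C)c12` differs from compound 3 in one place: 2-chloro-4,6-dimethylphenyl in place of 2-chloro-4-methoxyphenyl on an aromatic carbon. For the measured compounds named here, no measured pair in this set shows the effect of such a swap on the pendant phenyl, so any expectation rests on the range already seen. The three measured compounds all sit within a narrow band, and the change keeps the ring size, the chlorine and the heavy-atom count, so the step from compound 3 to compound 4 in this assay is expected to be small, a 1.2-fold lower number from compound 3 to compound 4 (0.08 log units; within the scatter), not clearly beyond the scatter in either direction. Compound 4 is therefore estimated at 4 nM, with a plausible range from 1.3 nM to 12 nM.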

Compound 4, inhibition constant: 2.1 nM
The estimate for compound 4 lay 1.9-fold (0.28 log units) above the measured number; the measured number falls inside the stated range.
By their numbers in this assay, from the lowest: compounds 1 and 4 (each within the scatter of the next); then compounds 3 and 2 (each within the scatter of the next).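

In this assay, for the compounds shown here, 2-chloro-4,6-dimethylphenyl in place of 2-chloro-4-methoxyphenyl gives a 2.3-fold lower number from compound 3 to compound 4 (0.36 log units; beyond the scatter), the only step in this set that isolates a change on the pendant phenyl. It shows that this position responds beyond the scatter to a swap that leaves the chlorine, the six-membered ring and the heavy-atom count unchanged, and that the number falls even though the entering group has no hydrogen-bond acceptor while the leaving group has one. Nothing available explains why the number moves in this direction.

The swap changes two things at once, so the compounds shown cannot separate the loss of the methoxy group from the gain of the methyl groups. Going by these compounds, it remains open how a 2-chloro-4-methoxy-6-methylphenyl group, or a trifluoromethyl or nitrile group on the pendant phenyl, would read in this assay.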